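Cytotoxicity limits ahead of a tert-butyl ester

The compounds below may be only part of what the source reports. "The series", "measured", "known", "first", "only" and "open" are said of these compounds alone.

In a functional assay on MT4 cells (Homo sapiens) for cytotoxicity (a higher number here means that more compound is tolerated, a lower number that less compound is tolerated), compound 1 (`Cc1cn(C2CC(N=[N+]=[N-])C(COC(=O)NCCCC(=O)O)O2)c(=O)[nH]c1=O`) gives > 50000 nM as a limit and not a number. Compound 2 (`Cc1cn(C2CC(N=[N+]=[N-])C(COC(=O)CCCC(=O)O)O2)c(=O)[nH]c1=O`) gives > 50000 nM as a limit too. Compound 3 (`Cc1cn(C2CC(N=[N+]=[N-])C(COC(=O)NCCCN)O2)c(=O)[nH]c1=O`) gives > 50000 nM as a limit as well, so it has no exact number of its own.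

Compound 4 (`Cc1cn(C2CC(N=[N+]=[N-])C(COC(=O)CCCC(=O)OC(C)(C)C)O2)c(=O)[nH]c1=O`) carries 3-(tert-butoxycarbonyl)propyl in place of (3-aminopropyl)amino on a carbonyl carbon. The closest guides are two swaps on a carbonyl carbon (a step that the two limits leave unreadable from compound 1 to compound 2; a step that the two limits leave unreadable from compound 2 to compound 3) and neither has a readable size. A swap at the end of the chain (a step that the two limits leave unreadable from compound 1 to compound 3) has none either. All three measured compounds share one reading (the limit of > 50000 nM in this assay, at which 3 of the 3 values shown sit) and so compound 4 is expected to stay close to it in this assay with no step beyond the scatter in either direction. The expected change is small (a number no higher from compound 3 to compound 4 (the limit leaves the size open)). For compound 4 the estimated value is 50000 nM with an expected range from 15000 nM to 100000 nM in this estimate.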

Compound 4, half-maximal cytotoxic concentration: > 50000 nM
Compound 4 was reported as a limit (the forecaster's own chance of this, stated with the estimate: 75%); the middle value lies on the limit itself.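

In this assay compound 4 gives > 50000 nM as a limit and not a number, so none of its steps from compound 1, compound 2 or compound 3 can be read. The compounds shown leave open whether any of these chain changes affects tolerated concentration, since no exact value exists for any of them.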